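Methoxy to trifluoromethoxy: working notes on the series

The compounds below may be only part of what the source reports. "The series", "measured", "known", "first", "only" and "open" are said of these compounds alone.

In a functional assay on Jurkat cells (Homo sapiens) for inhibition, read by MTT assay, with a stated time of 72 h (on this read-out lower numbers stand for stronger inhibition and higher numbers for weaker inhibition), compound 1 (`C=C(Br)C(=O)Nc1cccc(/C=C/C(=O)Nc2ccccc2)c1`) gives 5000 nM as its value, compound 2 (`C=C(Br)C(=O)Nc1cccc(/C=C/C(=O)Nc2ccc(F)cc2)c1`) gives 6200 nM and compound 3 (`C=C(Br)C(=O)Nc1cccc(/C=C/C(=O)Nc2ccc(OC)cc2)c1`) gives 470 nM as the lowest number of the three. The fluoro step shows a 1.2-fold higher number from compound 1 to compound 2 (0.09 log units; within the scatter) and no more. The methoxy steps are large, with an 11-fold lower number from compound 1 to compound 3 (1.03 log units; beyond the scatter) against hydrogen and a 13-fold lower number from compound 2 to compound 3 (1.12 log units; beyond the scatter) against fluoro.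

Compound 4 (`C=C(Br)C(=O)Nc1cccc(/C=C/C(=O)Nc2ccc(OC(F)(F)F)cc2)c1`) carries trifluoromethyl in place of methyl on an oxygen on an aromatic ring. Among the measured compounds shown here, no measured step alters that methyl, so the guidance is indirect. For the measured compounds named here, the new group keeps the oxygen of methoxy but also brings in fluorine, and the only fluorinated compound so far, compound 2, shows 6200 nM in the high range. Part of an 11-fold lower number from compound 1 to compound 3 (1.03 log units; beyond the scatter) is therefore expected to be lost, though not all of it. A higher number is expected, with a 3.2-fold higher number from compound 3 to compound 4 (0.50 log units; beyond the scatter) as the estimated step in this assay here. Compound 4 is estimated at 1500 nM with an expected range from 400 nM to 5500 nM in this assay for now.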

Compound 4, half-maximal inhibitory concentration: 30300 nM
Beside the measured number, compound 4's estimate is 20-fold (1.31 log units) below it; the whole stated range lies below it.
By their numbers in this assay, from the lowest: compound 3; then compounds 1 and 2 (each within the scatter of the next); then compound 4.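

In this assay the oxygen alone does not carry the gain at this position: with a 64-fold higher number from compound 3 to compound 4 (1.81 log units; beyond the scatter) as the step, replacing methyl by trifluoromethyl on that oxygen more than cancels the methoxy effect. The change also carries the series past the unsubstituted compound, with a 6.1-fold higher number from compound 1 to compound 4 (0.78 log units; beyond the scatter) as the step, and past the fluoro compound, with a 4.9-fold higher number from compound 2 to compound 4 (0.69 log units; beyond the scatter) as the step. This position can therefore move the number in either direction relative to hydrogen, with compound 3 on one side and compound 4 on the other, while compound 2 stays within the scatter of compound 1.

Still open, from the compounds shown here alone, is whether a hydroxyl, an ethoxy or a difluoromethoxy group on the same aromatic carbon would fall nearer compound 3 or compound 4. Nothing available explains the size of this swing.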